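The compounds below may be only part of what the source reports. "The series", "measured", "known", "first", "only" and "open" are said of these compounds alone.

Measured in a functional assay on HCT-15 cells (Homo sapiens) for cytotoxicity, read by sulforhodamine B assay, with a stated time of 72 h; a lower number here means a stronger inhibitor of growth, a higher number a weaker inhibitor of growth:
compound 1 `O=C(Nc1ccc(C(F)(F)F)cc1)C1CCc2ccccc2N1`: 17600 nM
compound 2 `CCCC(=O)N1c2ccccc2CCC1C(=O)Nc1cc(C(F)(F)F)cc(C(F)(F)F)c1`: 21900 nM

In this assay compound 2, at 21900 nM, lies within the scatter of compound 1, so the two values give no order. Compound 3 `O=C(Nc1cc(C(F)(F)F)cc(C(F)(F)F)c1)C1CCc2ccccc2N1` is still unmeasured. It follows from compound 2 with hydrogen in place of propylcarbonyl on a nitrogen on an aromatic ring in a ring. Within the data shown here, no measured step covers this change. Compound 1 also has hydrogen on that nitrogen and gives 17600 nM, so only a small shift toward a lower number is expected, probably within the scatter. The expected step is a 1.7-fold lower number from compound 2 to compound 3 (0.23 log units; within the scatter). For compound 3 the estimated value is 13000 nM, with an estimated range of 4500 nM to 30000 nM.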

Compound 3, concentration for 50% growth inhibition: 8700 nM
Compound 3: the middle estimate sits 1.5-fold (0.17 log units) above what was measured; measured number inside the range.
By their numbers in this assay, from the lowest: compound 3; then compounds 1 and 2 (each within the scatter of the next).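

In this assay, among these compounds, hydrogen in place of propylcarbonyl on this ring nitrogen gives the first step that can be read, a 2.5-fold lower number from compound 2 to compound 3 (0.40 log units; beyond the scatter), and it is modest. The propylcarbonyl group is therefore not needed for growth inhibition at this position, and the compound with hydrogen there gives the lower number of the pair. Nothing measured here explains the shift.

Open, on these data alone, is whether an acetyl, a benzoyl or a methyl group on this nitrogen would stay with compound 2 or with compound 3. Also open, as far as these compounds go, is whether a longer acyl chain would raise the number further.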